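A Methyl Added to Compound 3

The compounds below may be only part of what the source reports. "The series", "measured", "known", "first", "only" and "open" are said of these compounds alone.

Measured in an ADME assay on microsomes from liver (Mus musculus) for metabolic stability, read by LC-MS, with a stated time of 4 h, tested at 1 uM; on this read-out higher numbers stand for fast clearance and lower numbers for slow clearance:
- Compound 1 `CCOc1cc(NC(=O)NCc2cc(C)c(N3CC(C)OC(C)C3)cn2)cc(Cl)n1`: 500 mL/min/kg
- Compound 2 `Cc1cc(CNC(=O)Nc2cc(OCC(O)CO)nc(C(F)(F)F)c2)nnc1-c1cn(C)nc1C(F)(F)F`: < 76.7 mL/min/kg
- Compound 3 `Cc1cc(CNC(=O)Nc2cc(OCCO)nc(C(F)(F)F)c2)nnc1-c1cn(C)nc1C(F)(F)F`: 102 mL/min/kg

The value for compound 2 is a limit of the assay, not a number. Going by the values given here, only two compounds have actual numbers, and compound 3 has the lower one, at 102 mL/min/kg. Compound 1 gives 500 mL/min/kg. The gap between these two compounds lies beyond the scatter.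

The next compound is compound 4 `Cc1cc(CNC(=O)Nc2cc(C(F)(F)F)nc(OCCO)c2C)nnc1-c1cn(C)nc1C(F)(F)F`, which differs from compound 3 by one change: methyl in place of hydrogen on an aromatic carbon. The new methyl sits ortho to a 2-hydroxyethoxy group.

Among the compounds with values here, only one measured step exists: an at least 1.3-fold higher number from compound 2 to compound 3 (0.12 log units; that floor lies within the scatter). That change is on a saturated chain carbon, not an aromatic carbon, so it offers no direct guide. Within the data shown here, no measured step shows what a methyl does at this place, so no step beyond the scatter is expected, and the estimate stays close to compound 3: a 1.1-fold higher number from compound 3 to compound 4 (0.03 log units; within the scatter). For compound 4, the estimated clearance is 110 mL/min/kg, with an expected range from 65 mL/min/kg to 210 mL/min/kg.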

Compound 4, clearance: 91.7 mL/min/kg
Compound 4: middle estimate off by 1.2-fold (0.08 log units), on the high side; low and high end bracket the measured number.
By their numbers in this assay, from the lowest: compounds 4 and 3 (each within the scatter of the next); then compound 1. At a limit, below all of these: compound 2.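

Placing methyl in place of hydrogen on this aromatic carbon, ortho to a 2-hydroxyethoxy group, gives a result in this assay that stays within the scatter: a 1.1-fold lower number from compound 3 to compound 4 (0.05 log units; within the scatter). Going by these compounds alone, none of the earlier steps touched an aromatic carbon, so this pair is the first direct reading at this place. In this one pair, the position takes a methyl with no clearance change that can be told apart from the differences seen between repeated measurements.

From the compounds shown here alone, whether an ethyl, a chlorine or a methoxy group at the same place would behave in the same way stays open, as does the effect of this methyl on any other core. The low end of the read-out is also unresolved, with compound 2 given only as a limit of the assay: the limit of < 76.7 mL/min/kg in this assay, at which 1 of the 4 values shown sits.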